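Swapping pyrrolidin-2-yl for piperidin-2-yl on compound 1

The source may report more compounds than this note shows. Statements on the series, on what has been measured and on what is new or still open speak of the compounds shown alone.

Compound 1 `FC(F)(F)c1cc(NC[C@H]2CCCN2)c2cn[nH]c2c1` gives > 20000 nM as a limit
Compound 2 `O=[N+]([O-])c1ccc(CNc2cc(Br)cc3[nH]ncc23)cc1` gives > 20000 nM as a limit
Compound 3 `O=[N+]([O-])c1cc(Br)c(F)cc1CNc1cc(C(F)(F)F)cc2[nH]ncc12` gives 2820 nM as a number

In a functional assay on Jurkat cells (Homo sapiens) for inhibition, read by MTT assay, with a stated time of 24 h (on this read-out lower numbers stand for stronger inhibition and higher numbers for weaker inhibition), compound 1 gives > 20000 nM as its reading, which is a limit and not a number. Compound 2 also gives > 20000 nM as a limit. The overall picture is the limit of > 20000 nM in this assay, at which 2 of the 3 values shown sit, and compound 1 is one of those two. Compound 3 gives 2820 nM as a true number.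

Compound 4 `FC(F)(F)c1cc(NC[C@@H]2CCCCN2)c2cn[nH]c2c1` keeps the core of compound 1 and differs by piperidin-2-yl in place of pyrrolidin-2-yl on a saturated chain carbon bound to a nitrogen on an aromatic ring in one place, as (pyrrolidin-2-yl)methyl becomes (piperidin-2-yl)methyl. For the measured compounds named here, no measured pair shows this swap on its own in this assay at all. The expectation is no shift beyond the scatter in either direction, and it rests on compound 1 with > 20000 nM as its limit reading. The expected size is a number no higher from compound 1 to compound 4 (the limit leaves the size open) for this swap. Compound 4 is estimated at 20000 nM with an expected range from 8000 nM to 40000 nM and a reading at the limit is likely.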

Compound 4, half-maximal inhibitory concentration: > 20000 nM
Compound 4 gave a limit, no number; the forecaster's own chance of this, stated with the estimate: 75%; the middle value lies on the limit itself.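

In this assay, compound 1 and compound 4 each give only a limit and no number, so no step can be read from the swap of pyrrolidin-2-yl for piperidin-2-yl. The reading shared by most compounds here is that limit: the limit of > 20000 nM in this assay, at which 3 of the 4 values shown sit.

The compounds shown leave open how strongly, if at all, compound 1 and compound 4 differ.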